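Two stereocentres inverted in a sugar-derived somatostatin ligand

This account rests on a few compounds, and the source may have more. Where it says the series, first, only, none or still open, it means among the compounds named here.

Compound 1: `CS[C@@H]1O[C@H](COCc2ccc(Cl)cc2)[C@@H](O)[C@@H](OCc2ccc3ccccc3c2)[C@H]1NC(=O)CCCN=C(N)N`, 720 nM
Compound 2: `COC[C@H]1O[C@H](OCCc2ccccc2)[C@H](NC(=O)CCCN)[C@H](OCc2ccc3ccccc3c2)[C@@H]1O`, > 10000 nM

In an assay on CHO cells for displacement of a labelled ligand from somatostatin receptor type 4 (Homo sapiens) (a lower number here means a stronger inhibitor, a higher number a weaker inhibitor), compound 1 gives 720 nM. For compound 2 the assay reports only a limit, > 10000 nM, so no number is known for it; this is the limit of > 10000 nM in this assay, at which 1 of the 2 values shown sits. Compound 2 therefore stands at the weak end of what is shown, with compound 1 the only compound for which a value exists.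

Compound 3, `COC[C@H]1O[C@@H](OCCc2ccccc2)[C@H](NC(=O)CCCN)[C@@H](OCc2ccc3ccccc3c2)[C@@H]1O`, keeps every atom and bond of compound 2 and differs only in configuration: the two compounds have the same atoms and bonds and differ only in configuration as drawn: 2 of 5 stereo elements differ; a stereocentre at a saturated ring carbon is drawn S in compound 2 and R in compound 3; a stereocentre at a saturated ring carbon is drawn S in compound 2 and R in compound 3. Going by the values given here, since compound 2 sits at the limit of this assay, any step to compound 3 can only be towards stronger binding or none that can be seen; its size is unknown, as no comparable pair is available. The step from an at least 3.3-fold lower number from compound 2 to compound 3 (0.52 log units; beyond the scatter) is expected here. Compound 3 is estimated at 3000 nM, between 500 nM and 10000 nM.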

Compound 3, half-maximal inhibitory concentration: > 10000 nM
Compound 3 ended at the assay's limit; the forecaster's own chance of this, stated with the estimate: 40%; at least 3.3-fold (0.52 log units) between middle value and limit.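

Compound 3, like compound 2, ends at a limit of this assay and not at a number, so no step between these two compounds can be read: the limit of > 10000 nM in this assay, at which 2 of the 3 values shown sit.

As far as these compounds go, whether the two inverted stereocentres change binding at all, in either direction, stays open.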